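Swapping the aryl ketone partner of compound 1

This account rests on a few compounds, and the source may have more. Where it says the series, first, only, none or still open, it means among the compounds named here.

Compound 1 `CCCC(C)Oc1ccc(C(=O)/C=C/c2c(/C=C/c3ccc(OC)cc3)cc(OC)cc2OC)cc1` is one of three chalcone-type compounds sharing a core and tested in a functional assay on B16-F10 cells (Mus musculus) for antiproliferative activity, read by MTT assay, with a stated time of 48 h (a lower number here means a stronger inhibitor, a higher number a weaker inhibitor), where compound 1 gives 6.7 ug/mL. Compound 2 `COc1ccc(/C=C/c2cc(OC)cc(OC)c2/C=C/C(=O)c2ccc(F)cc2)cc1` gives 5.3 ug/mL in this assay, and compound 3 `COc1ccc(/C=C/c2cc(OC)cc(OC)c2/C=C/C(=O)c2ccccc2)cc1` gives 3.7 ug/mL. On these numbers compound 1 stands highest, yet its step to compound 2 a 1.3-fold lower number from compound 1 to compound 2 (0.10 log units; within the scatter) and its step to compound 3 a 1.8-fold lower number from compound 1 to compound 3 (0.26 log units; within the scatter) both stay inside the scatter of repeated measurements, so the three compounds cannot be told apart.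

Compound 4 `COc1ccc(/C=C/c2cc(OC)cc(OC)c2/C=C/C(=O)c2ccc(C)cc2C)cc1` has not yet been measured. It differs from compound 1 by one change (2,4-dimethylphenyl in place of 4-(1-methylbutoxy)phenyl on a carbonyl carbon). The two measured steps that bear on this are those from compound 1, each of which also removes the 1-methylbutoxy group from the aryl ketone: both gave a modestly lower number without leaving the scatter. A similar outcome is therefore expected for compound 4, a step of a 1.3-fold lower number from compound 1 to compound 4 (0.13 log units; within the scatter) in this assay, with no change beyond the scatter being the most likely reading. Compound 4 is estimated at 5 ug/mL, within a range of 2.5 ug/mL to 10 ug/mL.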

Compound 4, half-maximal inhibitory concentration: 4 ug/mL
Beside the measured number, compound 4's estimate is 1.3-fold (0.10 log units) above it; low and high end bracket the measured number.
By their numbers in this assay, from the lowest: compounds 3, 4, 2 and 1 (each within the scatter of the next).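

Compound 4 brings a ring with two methyl groups to the carbonyl carbon, and in this assay it still cannot be told apart from the other three compounds (a 1.7-fold lower number from compound 1 to compound 4 (0.22 log units; within the scatter); a 1.1-fold higher number from compound 3 to compound 4 (0.03 log units; within the scatter); a 1.3-fold lower number from compound 2 to compound 4 (0.12 log units; within the scatter)). All four aryl groups shown at this place, 4-(1-methylbutoxy)phenyl, 4-fluorophenyl, phenyl and 2,4-dimethylphenyl, therefore give numbers within the scatter of one another, so this assay tolerates two methyl groups on the ring as readily as the earlier groups. No supporting data are available to explain this flat result.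

The compounds shown leave open whether an aryl group carrying an amine or a carboxylic acid at this place would give a step beyond the scatter. They also do not show whether a single methyl group would behave as the two do here.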